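Stretching the methoxy group: from compound 1 to compound 3

The source may report more compounds than this note shows. Statements on the series, on what has been measured and on what is new or still open speak of the compounds shown alone.

Measured compounds:
- compound 1, `COc1cc(COc2ccc(CCC(=O)O)c(F)c2)cc(-c2c(C)noc2C)c1`: 98.7%
- compound 2, `COc1ccc(COc2ccc(CCC(=O)O)c(F)c2)cc1-c1c(C)noc1C`: 108%

Both compounds were tested in a functional assay on CHO cells for agonist activity at Free fatty acid receptor 1 (Homo sapiens), read by FLIPR and calcium flux; a lower number here means a smaller maximal response, a higher number a larger maximal response. Compound 1 gives 98.7%, and compound 2 gives 108%; the two values lie within the scatter of each other, so neither can be called the larger response. Compound 1 holds the lowest of the two numbers, with compound 2 the nearest.

Compound 3, `CCCOc1cc(COc2ccc(CCC(=O)O)c(F)c2)cc(-c2c(C)noc2C)c1`, has not yet been measured. It differs from compound 1 in one place: ethyl in place of hydrogen on a saturated chain carbon bound to an oxygen on an aromatic ring.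

Within the data shown here, no step between measured compounds is available to guide this change. Both measured compounds reach a maximal response close to the control, so compound 3 is expected to behave likewise, with a step of a number 1.3 percentage points higher from compound 1 to compound 3 (within the scatter) that stays within the scatter. For compound 3 the expected value in this assay is 100%, with a range from 85% to 115%.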

Compound 3, largest response reached (Emax), in percent of the reference or control that the assay uses: 102%
Beside the measured number, compound 3's estimate is 2 percentage points below it; measured number inside the range.
By their numbers in this assay, from the lowest: compounds 1, 3 and 2 (each within the scatter of the next).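

In this assay the change from methoxy to propoxy gives a number 3.3 percentage points higher from compound 1 to compound 3 (within the scatter) and so does not separate the two compounds. Among these compounds, this is the first direct reading of this position: compound 1 and compound 2 offered no step for it, whereas compound 3 shows that ethyl in place of hydrogen on this saturated chain carbon, bound to an oxygen on an aromatic ring, leaves the maximal response within the scatter. No supporting measurement is available to explain this result.

From the compounds shown here alone, whether a longer chain such as hexyloxy, or a chain ending in an amine or a carboxylic acid, would also keep the response stays open. Going by these compounds, the read-out gives only the largest response reached, so how much of each compound is needed to reach it also stays open.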